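A few compounds are considered here, and "the series" means these few. Any claim that something is new, unique, unknown or untested is made for them only; others in the source may bear on it.

Compound 3 `CC(=O)OC/C(=C\c1ccc(F)cc1)C(=O)c1ccccc1` in a functional assay on T47D cells (Homo sapiens) for inhibition, read by sulforhodamine B assay, with a stated time of 48 h (a lower number here means a stronger inhibitor of growth, a higher number a weaker inhibitor of growth), gives 14000 nM. Among the three compounds measured so far it stands second highest: compound 1 `CC(=O)OC/C(=C\c1ccccc1)C(=O)c1ccccc1` gives 16000 nM, and the step of a 1.1-fold lower number from compound 1 to compound 3 (0.06 log units; within the scatter) lies within the scatter, while compound 2 `CC(=O)OC/C(=C\c1ccc(Cl)cc1)C(=O)c1ccccc1` gives 5300 nM, and the step of a 2.6-fold higher number from compound 2 to compound 3 (0.42 log units; beyond the scatter) lies beyond it. Compound 4 `CC(=O)OC/C(=C\c1ccc([N+](=O)[O-])cc1)C(=O)c1ccccc1` differs from compound 3 in one place: nitro in place of fluoro on an aromatic carbon. The measured steps that bear on this change are the two that alter the group on an aromatic carbon, para to a large group: a 3.0-fold lower number from compound 1 to compound 2 (0.48 log units; beyond the scatter) and a 1.1-fold lower number from compound 1 to compound 3 (0.06 log units; within the scatter). Neither involves a nitro group, so they only show the range of what a change at this place has done, from no step beyond the scatter to a modest lowering of the number. On that basis the expected step is a modest one, a 1.8-fold lower number from compound 3 to compound 4 (0.24 log units; within the scatter), with the nitro group treated more like chloro than like fluoro. Compound 4 is therefore estimated at 8000 nM, with a likely range from 3000 nM to 25000 nM.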

Compound 4, concentration for 50% growth inhibition: 16000 nM
Beside the measured number, compound 4's estimate is 2.0-fold (0.30 log units) below it; low and high end bracket the measured number.
By their numbers in this assay, from the lowest: compound 2; then compounds 3, 1 and 4 (each within the scatter of the next).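

Within this assay the nitro group on this aromatic carbon gives no change at the digits printed from compound 1 to compound 4 (within the scatter) when it replaces hydrogen and a 1.1-fold higher number from compound 3 to compound 4 (0.06 log units; within the scatter) when it replaces fluoro, so hydrogen, fluoro and nitro cannot be told apart at this place. Chloro alone stands apart, with a 3.0-fold higher number from compound 2 to compound 4 (0.48 log units; beyond the scatter) when nitro replaces it, so the four compounds show no steady trend beyond that single group. Nothing shown here accounts for why only chloro differs at this place.

The compounds shown leave open whether an amine, a methoxy group or a bromo group at this place would side with chloro or with the other three. Going by these compounds, whether a change elsewhere on the shared core, such as a free hydroxyl group in place of the acetate ester, would move the number further also remains open.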